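Removing the methoxy group from compound 1

A few compounds are considered here, and "the series" means these few. Any claim that something is new, unique, unknown or untested is made for them only; others in the source may bear on it.

Compound 1 `C=CC(=O)N1C(=O)CC(c2ccc(OC)cc2)Sc2ccccc21` is measured in a functional assay on MOLT-4 cells (Homo sapiens) for cytotoxicity, read by CCK-8 assay, with a stated time of 24 h (a lower number here means a stronger inhibitor, a higher number a weaker inhibitor), where compound 1 gives 83200 nM. Compound 2 `C=CC(=O)N1C(=O)CC(c2ccc(-c3ccccc3)cc2)Sc2ccccc21` gives 97500 nM, and compound 3 `C=CC(=O)N1C(=O)CC(c2cccs2)Sc2ccccc21` gives 557000 nM. Of the three numbers, compound 1 and compound 2 sit close together, the step being a 1.2-fold higher number from compound 1 to compound 2 (0.07 log units; within the scatter), while the step to compound 3 is a 6.7-fold higher number from compound 1 to compound 3 (0.83 log units; beyond the scatter). Compound 4 `C=CC(=O)N1C(=O)CC(c2ccccc2)Sc2ccccc21` differs from compound 1 as follows: hydrogen in place of methoxy on an aromatic carbon. The change at the same aromatic carbon from compound 1 to compound 2 stayed within the scatter, whereas losing the whole 4-methoxyphenyl group in compound 3 gave a modest rise. Compound 4 is therefore expected to show a step of a 1.3-fold higher number from compound 1 to compound 4 (0.12 log units; within the scatter), little beyond the scatter. The estimate for compound 4 in this assay is 110000 nM, within 50000 nM to 250000 nM.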

Compound 4, half-maximal inhibitory concentration: 85900 nM
Estimate against measurement, compound 4: 1.3-fold (0.11 log units) above; measured number inside the range.
By their numbers in this assay, from the lowest: compounds 1, 4 and 2 (each within the scatter of the next); then compound 3.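

At this aromatic carbon, hydrogen, methoxy and phenyl cannot be told apart in this assay: a 1.0-fold higher number from compound 1 to compound 4 (0.01 log units; within the scatter) and a 1.1-fold lower number from compound 2 to compound 4 (0.06 log units; within the scatter) both stay within the scatter, so neither substituent is needed to reach this level. The step of a 6.5-fold lower number from compound 3 to compound 4 (0.81 log units; beyond the scatter) now compares phenyl with thiophen-2-yl directly, with no substituent on the phenyl involved. No available evidence bears on these readings. As far as these compounds go, whether an amine or a carboxylic acid at this aromatic carbon would stay in the same range remains open. Also open, from the compounds shown here alone, is whether another five-membered aromatic ring would match thiophen-2-yl.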